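The source may hold more compounds than are shown below. What is called first, only, known or untested is meant among the compounds shown, and "the series" means these compounds.

Compound 1 `Cc1cc(N2CCCC(O)C2)c(S(C)(=O)=O)cc1C(=O)N=C(N)N`: 30 nM
Compound 2 `Cc1cn(-c2cc(C)c(C(=O)N=C(N)N)cc2S(C)(=O)=O)cn1`: 28 nM

Among the compounds with values here, compound 2 shows the lowest of the two numbers so far recorded in a functional assay for inhibition of sodium/hydrogen exchanger (Oryctolagus cuniculus); on this read-out lower numbers stand for stronger inhibition and higher numbers for weaker inhibition. Its nearest neighbour is compound 1, and the step of a 1.1-fold lower number from compound 1 to compound 2 (0.03 log units; within the scatter) lies within the scatter, so no order between the two can be claimed. Compound 3 `Cc1cc(C#N)c(S(C)(=O)=O)cc1C(=O)N=C(N)N` has not yet been measured. Its change from compound 2 is cyano in place of 4-methyl-1H-imidazol-1-yl on an aromatic carbon. Within the data shown here, the only measured step that bears on this position is a 1.1-fold lower number from compound 1 to compound 2 (0.03 log units; within the scatter), in which one group was exchanged for another at the same place without a change beyond the scatter. On that basis the exchange for cyano is expected to leave the number in this assay close to where compound 2 stands, with a modest widening of the range for the unknown. Compound 3 is therefore expected to give about 40 nM, within a range from 12 nM to 130 nM. The implied step a 1.4-fold higher number from compound 2 to compound 3 (0.15 log units; within the scatter) is expected to remain near the scatter.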

Compound 3, half-maximal inhibitory concentration: 70 nM
For compound 3 the middle estimate is 1.8-fold (0.24 log units) below the measured one; low and high end bracket the measured number.
By their numbers in this assay, from the lowest: compounds 2 and 1 (each within the scatter of the next); then compound 3.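

In this assay this position no longer appears indifferent to the group it carries: a 2.5-fold higher number from compound 2 to compound 3 (0.40 log units; beyond the scatter) and a 2.3-fold higher number from compound 1 to compound 3 (0.37 log units; beyond the scatter) both lie beyond the scatter, whereas the exchange of one ring-bearing group for the other stayed within it. 4-Methyl-1H-imidazol-1-yl and 3-hydroxypiperidin-1-yl therefore stand together, while cyano, with 2 heavy atoms and no ring, stands apart from both by a modest step. Nothing available here accounts for this difference.

The compounds shown leave open whether an open-chain amine such as dimethylamino, or a single chlorine atom, on this aromatic carbon would stand with cyano or with the two ring-bearing groups. They also leave open whether a step of this size would persist if the methylsulfonyl group were replaced by another group.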